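A few compounds are considered here, and "the series" means these few. Any claim that something is new, unique, unknown or untested is made for them only; others in the source may bear on it.

Compound 1 `CC(=O)NCC#Cc1ccc2c(c1)C=C([N+](=O)[O-])C(C(F)(F)F)O2`: 4400 nM in an assay on isolated protein for inhibition of Sigma non-opioid intracellular receptor 1 (Homo sapiens); on this read-out higher numbers stand for weaker inhibition and lower numbers for stronger inhibition
Compound 2 `C[Si](C)(C)C#Cc1ccc2c(c1)C=C([N+](=O)[O-])C(C(F)(F)F)O2`: 1400 nM in this assay

Within the data shown here, compound 2 gives the lowest of the two numbers in this assay; the only measured step is a 3.1-fold lower number from compound 1 to compound 2 (0.50 log units; beyond the scatter). Compound 3 `O=[N+]([O-])C1=Cc2cc(I)ccc2OC1C(F)(F)F` differs from compound 2 by one iodine atom in place of a group of 6 heavy atoms (5 carbon, 1 silicon; no ring), on an aromatic carbon, a change of a different kind from the measured step, which only exchanged the ends of the triple bond. Among the measured compounds shown here, no measured step therefore bears directly on it, and the reasonable expectation is a change within the scatter, with iodo treated as another small, uncharged substituent, so a 1.2-fold lower number from compound 2 to compound 3 (0.07 log units; within the scatter) is expected. Compound 3 is estimated at 1200 nM, between 300 nM and 5000 nM.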

Compound 3, inhibition constant: 2100 nM
Beside the measured number, compound 3's estimate is 1.8-fold (0.24 log units) below it; the range from low to high includes it.
By their numbers in this assay, from the lowest: compounds 2 and 3 (each within the scatter of the next); then compound 1.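

Exchanging the silicon-bearing group and its triple bond for one iodine atom gives a 1.5-fold higher number from compound 2 to compound 3 (0.18 log units; within the scatter) in this assay, so a triple bond is not required on this aromatic carbon for a number of this size. Iodo in place of 3-acetamidoprop-1-yn-1-yl gives a 2.1-fold lower number from compound 1 to compound 3 (0.32 log units; beyond the scatter), which leaves compound 1 apart from compound 2 and compound 3. Nothing available explains these numbers. On these data alone, whether a chlorine atom, an amine or a carboxylic acid on this carbon would give a number apart from these remains open.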